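The source may hold more compounds than are shown below. What is called first, only, known or untested is meant among the compounds shown, and "the series" means these compounds.

Measured compounds:
- compound 1, `CCOC(=O)c1c(C)nc(-c2cccc(C#N)c2)n1OC(C)C`, 6740 nM
- compound 2, `CCOCCOn1c(-c2cccc(C#N)c2)nc(C)c1C(=O)OCC`, 6250 nM
- compound 3, `CCOC(=O)c1c(C)nc(-c2cccc(C#N)c2)n1OCc1ccc(OC)cc1`, 6830 nM

These three share one core and differ only in the group carried on an oxygen on an aromatic ring. In a functional assay on a cell-free system (plasma, Oryctolagus cuniculus) for inhibition, with stated times of 5 min, 1 min and 6 min (a lower number here means a stronger inhibitor, a higher number a weaker inhibitor), compound 2 gives the lowest of the three numbers, but the gaps to compound 1 and to compound 3 both lie within the scatter, so no order among them can be claimed.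

Compound 4, `CCOC(=O)c1c(C)nc(-c2cccc(C#N)c2)n1OCc1cccc(C#N)c1`, has not yet been measured. Relative to compound 2 the change is 3-cyanophenyl in place of ethoxymethyl on a saturated chain carbon bound to an oxygen on an aromatic ring.

The measured steps bear on this directly, since each also swaps the group at this oxygen: a 1.1-fold lower number from compound 1 to compound 2 (0.03 log units; within the scatter), a 1.0-fold higher number from compound 1 to compound 3 (0.01 log units; within the scatter) and a 1.1-fold higher number from compound 2 to compound 3 (0.04 log units; within the scatter). None moved the number beyond the scatter, whether the group was small or carried an aromatic ring. A step from compound 2 to compound 4 of no size beyond the scatter is therefore expected, in either direction; the expected step is a 1.0-fold higher number from compound 2 to compound 4 (0.02 log units; within the scatter). Compound 4 is estimated at 6500 nM, with a range from 3000 nM to 14000 nM.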

Compound 4, half-maximal inhibitory concentration: > 30000 nM
Compound 4 ended at the assay's limit; the forecaster's own chance of this, stated with the estimate: 10%; middle value at least 4.6-fold (0.66 log units) from the limit.
By their numbers in this assay, from the lowest: compounds 2, 1 and 3 (each within the scatter of the next). At a limit, above all of these: compound 4.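

Compound 4 stands at a limit of this assay, so it has no exact number: the limit of > 30000 nM in this assay, at which 1 of the 4 values shown sits. This position is therefore not as indifferent to change as the first three compounds suggested, since all three new steps lie beyond the scatter: an at least 4.8-fold higher number from compound 2 to compound 4 (0.68 log units; beyond the scatter), an at least 4.3-fold higher number from compound 3 to compound 4 (0.64 log units; beyond the scatter) and an at least 4.4-fold higher number from compound 1 to compound 4 (0.64 log units; beyond the scatter). The step from compound 3 is the most telling. An aromatic ring is present on this saturated chain carbon on both sides of that step. A ring there is not enough to raise the number, and the change goes with 3-cyanophenyl in place of 4-methoxyphenyl.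

How a plain benzyl or a 4-cyanobenzyl would behave here remains open, so the compounds shown cannot separate the effect of having a nitrile from that of where it sits on the ring. As far as these compounds go, the true size of all three steps also stays unknown, as compound 4 gives only a limit.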